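The source may hold more compounds than are shown below. What is called first, only, known or untested is meant among the compounds shown, and "the series" means these compounds.

Compound 3 `O=C(CCc1ccc(-c2cccc(F)c2)cc1)N1CCCC1` is the reference point for this step. In an assay on HEK293 cells for inhibition of N-acylethanolamine-hydrolyzing acid amidase (Rattus norvegicus), read by LC-MS, with a stated time of 30 min (a lower number here means a stronger inhibitor, a higher number a weaker inhibitor), compound 3 gives 1800 nM, the lowest of the two numbers shown, with compound 2 `Cc1ccc(-c2ccc(CCC(=O)N3CCCC3)cc2)cc1` as its nearest neighbour at 33200 nM. For compound 1 `Cc1ccccc1-c1ccc(CCC(=O)N2CCCC2)cc1` only a limit of the assay is reported, > 100000 nM, as recorded under (the limit of > 100000 nM in this assay, at which 1 of the 3 values shown sits). The measured steps all concern the substituent pattern on the outer ring: an at least 3.0-fold lower number from compound 1 to compound 2 (0.47 log units; beyond the scatter), an at least 55-fold lower number from compound 1 to compound 3 (1.74 log units; beyond the scatter) and an 18-fold lower number from compound 2 to compound 3 (1.27 log units; beyond the scatter). Compound 4 `O=C(CCc1ccc(-c2cccc(Cl)c2)cc1)N1CCCC1` differs from compound 3 by chloro in place of fluoro on an aromatic carbon. For the measured compounds named here, none of the measured steps exchanges one halogen for another; they show that moving or changing the group on that ring can shift this assay by large amounts, but give no direct precedent for a fluoro-to-chloro swap at the same position. Compound 4 is therefore expected to stay close to compound 3, with a step of a 1.4-fold lower number from compound 3 to compound 4 (0.14 log units; within the scatter) that is unlikely to reach beyond the usual scatter. The estimate for compound 4 in this assay is 1300 nM, with a range from 450 nM to 4000 nM.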

Compound 4, half-maximal inhibitory concentration: 25400 nM
Compound 4: the middle estimate sits 20-fold (1.29 log units) below what was measured, outside the stated range (above it).
By their numbers in this assay, from the lowest: compound 3; then compounds 4 and 2 (each within the scatter of the next). At a limit, above all of these: compound 1.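

In this assay, the change from 3-fluorophenyl to 3-chlorophenyl gives a 14-fold higher number from compound 3 to compound 4 (1.15 log units; beyond the scatter), so exchanging one halogen for another on an aromatic carbon, meta to a large group, is a large step on its own, with no ring added and the counts of hydrogen-bond donors and acceptors unchanged. Fluoro and chloro are therefore not interchangeable at this place, and the 3-chlorophenyl group cannot be told apart from the 4-methylphenyl group, with a 1.3-fold lower number from compound 2 to compound 4 (0.12 log units; within the scatter). The remaining step, an at least 3.9-fold lower number from compound 1 to compound 4 (0.59 log units; beyond the scatter), starts from a limit of the assay and so gives only a bound: the limit of > 100000 nM in this assay, at which 1 of the 4 values shown sits.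

The compounds shown leave open whether the low number of compound 3 is particular to fluoro or would also be reached with a hydrogen, a methoxy group or a nitrile at this place, or with a second fluoro on the outer ring. They also leave open whether the step from fluoro to chloro would keep its size with a longer chain in the shared core.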